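A few compounds are considered here, and "the series" means these few. Any claim that something is new, unique, unknown or untested is made for them only; others in the source may bear on it.

Measured compounds:
- compound 1, `CC(=O)c1ccc(NC(=O)Nc2cc(C)nc3ccccc23)cc1`, a limit in this assay: > 25000 nM
- compound 2, `Cc1cc(NC(=O)Nc2ccc([N+](=O)[O-])c(C(F)(F)F)c2)c2ccccc2n1`, also a limit: > 25000 nM

Both compounds were tested in an ADME assay on Raji cells (Homo sapiens) for cytotoxicity, with a stated time of 72 h (a higher number here means that more compound is needed for the effect, a lower number that less compound is needed), and neither gave a number. Compound 1 therefore stands at the edge of what the assay reports, and (the limit of > 25000 nM in this assay, at which 2 of the 2 values shown sit). Compound 3 `Cc1cc(NC(=O)Nc2ccc(C(=O)O)cc2)c2ccccc2n1` differs from compound 1 by hydroxy in place of methyl on a carbonyl carbon. Going by the values given here, no measured pair shows a change of this kind, so no step beyond the scatter is expected; a further limit seems the likeliest outcome. Compound 3 is estimated at 30000 nM, within 15000 nM to 60000 nM. That estimate is expected to mean a step that the limit leaves unreadable from compound 1 to compound 3.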

Compound 3, half-maximal effective concentration: > 25000 nM
Compound 3: a limit, no number; the forecaster's own chance of this, stated with the estimate: 85%; the middle value is on the limit's open side.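

No step can be read between compound 1 and compound 3, because each result is a limit and not a number: the limit of > 25000 nM in this assay, at which 3 of the 3 values shown sit.

The compounds shown leave open what structural change, if any, would give a measurable value in this assay.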